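Adding a chloro group to compound 2

This account rests on a few compounds, and the source may have more. Where it says the series, first, only, none or still open, it means among the compounds named here.

In a functional assay on HT-29 cells (Homo sapiens) for antiproliferative activity, with a stated time of 72 h (a lower number here means a stronger inhibitor, a higher number a weaker inhibitor), compound 1 `Cn1c(N2N=C(c3ccc(Cl)cc3)CC2c2ccccc2)nc(-c2ccccc2)c(C#N)c1=O` gives 6600 nM and compound 2 `COc1ccc(C2CC(c3ccc(Cl)cc3)=NN2c2nc(-c3ccccc3)c(C#N)c(=O)n2C)cc1` gives 9120 nM as its reading, so these two values sit within the usual scatter of each other. Compound 3 `COc1ccc(C2CC(c3ccc(Cl)cc3)=NN2c2nc(-c3ccc(Cl)cc3)c(C#N)c(=O)n2C)cc1` is compound 2 with chloro in place of hydrogen on an aromatic carbon, which turns a phenyl into a 4-chlorophenyl. Among the measured compounds shown here, only one measured step bears on this: a 1.4-fold higher number from compound 1 to compound 2 (0.14 log units; within the scatter), with methoxy in place of hydrogen on an aromatic carbon. For the measured compounds named here, that is a different group at a different place, so it offers only a loose guide, and no measured step shows what chloro does here. No shift beyond the scatter is therefore expected in this assay. The estimated change is a 1.2-fold lower number from compound 2 to compound 3 (0.08 log units; within the scatter), and it is expected to stay small. For compound 3 the expected value is 7500 nM, with an estimated range from 2800 nM to 20000 nM.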

Compound 3, half-maximal inhibitory concentration: 15100 nM
Compound 3: middle estimate off by 2.0-fold (0.30 log units), on the low side, within the range that was stated.
By their numbers in this assay, from the lowest: compounds 1, 2 and 3 (each within the scatter of the next, the first and the last beyond it).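

In this assay, among the compounds shown here, the change from phenyl to 4-chlorophenyl gives a 1.7-fold higher number from compound 2 to compound 3 (0.22 log units; within the scatter) and so gives the first reading at this position, on the aromatic ring that carries no methoxy. For the compounds shown here, the only earlier step concerned a methoxy group on a different ring, so this result adds that a single chloro, para to a large group, does not move the number beyond the usual scatter. No supporting measurement is available to account for this reading.

A single small atom at one place says little about how much this position can tolerate overall. From the compounds shown here alone, whether a larger or quite different group here, such as an amine or a carboxylic acid, would shift the number beyond the scatter remains open.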